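Sulfonyl aryl variation in the quinoline sulfone series

The source may hold more compounds than are shown below. What is called first, only, known or untested is meant among the compounds shown, and "the series" means these compounds.

Measured compounds:
- compound 1, `COc1cccc(-c2c(S(=O)(=O)c3ccc(C)c(F)c3)cnc3c(F)cccc23)c1`: 4.02 mL/min
- compound 2, `COc1ccc(-c2c(S(=O)(=O)c3ccc(C)c(F)c3)cnc3c(F)cccc23)cc1`: 3.27 mL/min
- compound 3, `O=S(=O)(c1cc(Cl)cc(Cl)c1)c1cnc2cc(F)ccc2c1-c1ccccc1F`: 0.93 mL/min

In an ADME assay on microsomes from liver (Homo sapiens) for metabolic stability, tested at 2.5 uM (on this read-out higher numbers stand for fast clearance and lower numbers for slow clearance), compound 1 gives 4.02 mL/min, the highest of the three numbers. Compound 2 sits nearest, and the step of a 1.2-fold lower number from compound 1 to compound 2 (0.09 log units; within the scatter) is within the scatter, so the two are not distinguished. Among the measured compounds shown here, compound 3 gives 0.93 mL/min, the lowest number of the three; it differs from compound 1 in several places at once, so no single step can be drawn from it.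

Compound 4, `COc1cccc(-c2c(S(=O)(=O)c3cc(F)cc(F)c3)cnc3c(F)cccc23)c1`, is not yet measured. It differs from compound 1 in one place: 3,5-difluorophenyl in place of 3-fluoro-4-methylphenyl on a sulfonyl sulfur. For the measured compounds named here, no measured step touches the sulfonyl aryl group: the only step in hand, from compound 1 to compound 2, moves a methoxy group and says nothing about this position. Compound 3 also carries a 3,5-disubstituted aryl on the sulfonyl sulfur, but with chlorine and with other changes elsewhere, so only its value can be noted.

Going by the values given here, with no directly relevant step, the expectation for compound 4 rests on compound 1 alone, and the estimated step of a 1.3-fold lower number from compound 1 to compound 4 (0.10 log units; within the scatter) is taken as small, with a wide range in either direction. Compound 4 is therefore expected to give about 3.2 mL/min in this assay, between 1.3 mL/min and 7 mL/min.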

Compound 4, intrinsic clearance in a liver preparation (reported as CLH), per the amount of preparation that the assay uses: 2.76 mL/min
Beside the measured number, compound 4's estimate is 1.2-fold (0.06 log units) above it; measured number inside the range.
By their numbers in this assay, from the lowest: compound 3; then compounds 4, 2 and 1 (each within the scatter of the next).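

Among the compounds shown here, this is the first step that touches the aryl group on the sulfonyl sulfur. In this assay, 3,5-difluorophenyl in place of 3-fluoro-4-methylphenyl gives a 1.5-fold lower number from compound 1 to compound 4 (0.16 log units; within the scatter), so compound 1 and compound 4 are not told apart, even though one carbon of the group gives way to a fluorine at an equal count of heavy atoms. No data at hand bear on the reason for this result.

The compounds shown leave open whether the number stays within the scatter with a group of a different kind on this aryl ring, such as an amine, a carboxylic acid or a longer alkoxy chain, given that both aryl groups compared here carry only carbon and fluorine. Also open, going by these compounds, is which of the several differences separates compound 3, at 0.93 mL/min in this assay, from compound 1, and whether the sulfonyl aryl group contributes to that gap at all.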